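This account rests on a few compounds, and the source may have more. Where it says the series, first, only, none or still open, it means among the compounds named here.

Working notes on the ester series in a functional assay, tested at 200 ug/mL; a lower number here means a stronger effect, a higher number a weaker effect of the compound at the concentration tested.

Compound 2 `COC(=O)C1=C(C)N(c2ccccc2)C=CC1c1ccccc1` carries a methoxycarbonyl group and gives -43% in this assay. Its ethyl counterpart, compound 1 `CCOC(=O)C1=C(C)N(c2ccccc2)C=CC1c1ccccc1`, gives -34%. Compound 2 has the lowest of the two numbers recorded so far, but its nearest neighbour compound 1 stands only a number 9 percentage points lower from compound 1 to compound 2 (within the scatter) away, so the two values cannot be ranked against each other.

Compound 3 `CC1=C(C(=O)OC(C)(C)C)C(c2ccccc2)C=CN1c1ccccc1` is the next member, not yet measured in this assay. It differs from compound 2 in one place: tert-butyl in place of methyl on an oxygen next to a carbonyl group.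

Within the data shown here, the only measured step that bears on this change is the one between compound 1 and compound 2, which also alters the alkyl group on the oxygen next to the carbonyl group; that step was a number 9 percentage points lower from compound 1 to compound 2 (within the scatter) and lies within the scatter. A further enlargement of that same group therefore gives no basis to expect a step beyond the scatter in either direction.

For compound 3 the expected step is a number 5 percentage points higher from compound 2 to compound 3 (within the scatter). Compound 3 is thus estimated at -38%, with a range from -60% to -15%.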

Compound 3, a percentage reported as activity, at one concentration (the size of the read-out at that concentration, not a potency): -52.9%
Compound 3: the middle estimate sits 14.9 percentage points above what was measured; low and high end bracket the measured number.
By their numbers in this assay, from the lowest: compounds 3, 2 and 1 (each within the scatter of the next, the first and the last beyond it).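

Tert-butoxycarbonyl in place of methoxycarbonyl gives a number 9.9 percentage points lower from compound 2 to compound 3 (within the scatter) in this assay, so the larger group on an oxygen next to a carbonyl group cannot be told apart from methyl at this concentration. Among these compounds, the position is not silent, though: tert-butyl in place of ethyl gives a number 18.9 percentage points lower from compound 1 to compound 3 (beyond the scatter), the first step at this place to clear the scatter, while compound 2 stays within the scatter of both neighbours, so the three esters show no established stepwise order with chain size. Nothing measured in this set accounts for the numbers.

The compounds shown leave open how this position reads with a benzyl group on the oxygen, or with a carboxylic acid or an amide in place of the ester. They also all keep the same phenyl groups on the shared core, so a chlorine on either phenyl, or a pyridine in its place, remains an open question, as does any read-out beyond the single concentration tested.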